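The compounds below may be only part of what the source reports. "The series", "measured", "known", "first", "only" and "open" are said of these compounds alone.

Of the compounds shown here, three sharing one core have been tested in an ADME assay on MRC5 cells (Homo sapiens), read by MTT assay, with a stated time of 72 h; a lower number here means a stronger inhibitor, a higher number a weaker inhibitor. Compound 1 (`CNc1ncnc2c1c(-c1cccs1)cn2[C@@H]1O[C@H](CO)[C@@H](O)[C@H]1O`) gives > 100000 nM, which is a limit of the assay and not a number. Compound 2 (`CNc1ncnc2c1c(-c1ccsc1)cn2[C@@H]1O[C@H](CO)[C@@H](O)[C@H]1O`) gives > 100000 nM, again a limit. For the measured compounds named here, compound 3 (`CNc1ncnc2c1c(-c1cc3ccccc3o1)cn2[C@@H]1O[C@H](CO)[C@@H](O)[C@H]1O`) gives 75300 nM, the only actual number so far.

The next step leads to compound 4 (`CNc1ncnc2c1c(I)cn2[C@@H]1O[C@H](CO)[C@@H](O)[C@H]1O`), with iodo in place of 1-benzofuran-2-yl on an aromatic carbon.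

Going by the values given here, three measured steps bear on this change, and none of them is a firm guide. Among the compounds with values here, the first is a step that the two limits leave unreadable from compound 1 to compound 2. The other two, both ending at compound 3, are an at least 1.3-fold lower number from compound 1 to compound 3 (0.12 log units; that floor lies within the scatter) and an at least 1.3-fold lower number from compound 2 to compound 3 (0.12 log units; that floor lies within the scatter). Within the data shown here, each of these exchanges one aromatic ring group for another, whereas iodo brings no ring at all, so the new step has no direct precedent.

Only a modest move towards a lower number is therefore expected, and its direction is uncertain: the estimate is a 2.2-fold lower number from compound 3 to compound 4 (0.33 log units; beyond the scatter). For compound 4 the expected value is 35000 nM, with an estimated range from 4000 nM to 120000 nM.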

Compound 4, half-maximal inhibitory concentration: > 100000 nM
Compound 4 gave a limit, no number; the forecaster's own chance of this, stated with the estimate: 30%; middle value at least 2.8-fold (0.45 log units) away from the limit.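

Swapping the ring group at this position for a single iodine atom does not yield a readable number: in this assay compound 4 gives > 100000 nM, which is a limit of the assay and not a number. For the compounds shown here, the one step that can be read is an at least 1.3-fold higher number from compound 3 to compound 4 (0.12 log units; that floor lies within the scatter), so the data establish no real change, only that iodo, a group with no ring, does not bring the value under the limit; the steps to compound 4 from compound 1 and compound 2 cannot be read. Compound 3 therefore remains the only compound with an actual number, and little more can be said about this position because the values gather at a single ceiling: the limit of > 100000 nM in this assay, at which 3 of the 4 values shown sit.

On these data alone, how far compound 1, compound 2 and compound 4 lie beyond that limit, and whether they differ from one another at all, remains open. Also open, as far as these compounds go, is how other groups on this aromatic carbon would read, such as an amine, a carboxylic acid or a longer chain, or a larger fused ring group than the 1-benzofuran-2-yl of compound 3.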